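Aminopropyl in place of aryl ether on bromopyrimidine core

A few compounds are considered here, and "the series" means these few. Any claim that something is new, unique, unknown or untested is made for them only; others in the source may bear on it.

Two compounds of the series have numbers in a functional assay on MDA-MB-468 cells (Homo sapiens) for antiproliferative activity, read by MTT assay, with a stated time of 24 h; a lower number here means a stronger inhibitor, a higher number a weaker inhibitor. Compound 1 `CNC(=O)c1ccccc1Oc1nc(Nc2cccc(C(F)(F)F)c2)ncc1Br` gives 32800 nM. Compound 2 `COc1cc(Nc2ncc(Br)c(Oc3ccc([N+](=O)[O-])cc3F)n2)cc(OC)c1OC` gives 16800 nM, the lower of the two, though the gap to compound 1 stays within the usual scatter, so no order between them can be read from these two numbers.

Compound 3 `COc1cc(Nc2ncc(Br)c(ONCCCN)n2)cc(OC)c1OC` keeps the shared core of compound 2 and changes only one place: (3-aminopropyl)amino in place of 2-fluoro-4-nitrophenyl on an oxygen on an aromatic ring. Among the compounds with values here, no measured pair shows what such a change does, so the expectation rests on the level of compound 2 alone. The expected step is a 2.1-fold higher number from compound 2 to compound 3 (0.32 log units; beyond the scatter), a mild weakening that may well fall inside the scatter. For compound 3 the estimate in this assay is 35000 nM, with a range from 9000 nM to 140000 nM, and a fair chance that only a limit is reported.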

Compound 3, half-maximal inhibitory concentration: 33100 nM
The estimate for compound 3 lay 1.1-fold (0.02 log units) above the measured number; the range from low to high includes it.
By their numbers in this assay, from the lowest: compounds 2, 1 and 3 (each within the scatter of the next).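

In this assay, within the data shown here, the replacement gives a 2.0-fold higher number from compound 2 to compound 3 (0.29 log units; within the scatter) and so provides the first reading of a change on this oxygen on an aromatic ring. The two numbers cannot be told apart, even though the 2-fluoro-4-nitrophenyl group with its aromatic ring gives way to the ringless (3-aminopropyl)amino group. On this one pair, the ring and its fluorine and nitro groups are not needed to keep the number at the level of compound 2, and nothing available explains this result.

From the compounds shown here alone, it remains open whether a plain phenyl group on the same oxygen, or a longer chain ending in the same amine, would separate from compound 2 beyond the scatter. A carboxylic acid in place of that amine is equally unresolved.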